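Swapping the Amide Partner on an Indole Acrylonitrile

The source may report more compounds than this note shows. Statements on the series, on what has been measured and on what is new or still open speak of the compounds shown alone.

Compound 1 `COc1ccc2[nH]c(-c3ccccc3)c(C=C(C#N)C#N)c2c1`: 1000 nM
Compound 2 `CCOC(=O)/C(=C/c1c[nH]c2ccccc12)C(=O)c1ccc([N+](=O)[O-])cc1`: 100000 nM
Compound 3 `N#C/C(=C\c1c(-c2ccccc2)[nH]c2ccccc12)C(=O)N1CCCCC1`: 9600 nM

These three values come from a functional assay on MT4 cells (Homo sapiens) for antiproliferative activity, read by MTT assay, with a stated time of 96 h; a higher number here means that more compound is needed for the effect, a lower number that less compound is needed. Among them compound 3 holds the middle place: compound 1 gives a clearly lower number, compound 2 a clearly higher one, and both gaps lie beyond the usual scatter of this assay. Compound 3 is therefore neither the most nor the least potent of the three.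

The next compound, compound 4 `N#C/C(=C\c1c(-c2ccccc2)[nH]c2ccccc12)C(=O)Nc1ccc(Cl)cc1`, keeps the whole of compound 3 apart from one change: (4-chlorophenyl)amino in place of piperidin-1-yl on a carbonyl carbon. The amide carbonyl stays; only the group on its nitrogen side is exchanged, and that group now carries a hydrogen-bond donor where none was before.

For the measured compounds named here, no pair among the measured compounds shows this particular exchange, so there is no measured step to lean on. The expectation is a small shift at most, likely within the scatter of this assay, with a slight lean toward a lower number. Compound 4 is thus expected to give about 7000 nM, somewhere between 1500 nM and 30000 nM. That estimate means a step from compound 3 to compound 4 of a 1.4-fold lower number from compound 3 to compound 4 (0.14 log units; within the scatter).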

Compound 4, half-maximal effective concentration: 1700 nM
Compound 4: the middle estimate sits 4.1-fold (0.61 log units) above what was measured; measured number inside the range.
By their numbers in this assay, from the lowest: compounds 1 and 4 (each within the scatter of the next); then compound 3; then compound 2.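

In this assay, putting (4-chlorophenyl)amino in place of piperidin-1-yl on the carbonyl carbon gives a 5.6-fold lower number from compound 3 to compound 4 (0.75 log units; beyond the scatter), so the group at this place does change the number. The exchange alters several things at once: an aromatic ring replaces a non-aromatic one, the amide hydrogen appears as a hydrogen-bond donor, and a chlorine enters, and this single step cannot separate these changes. No measurement offered here explains the shift.

The compounds shown leave open whether plain phenylamino, without the chlorine, would give a similar number, which would show what the chlorine contributes. Also open, going by these compounds, is how a benzylamino group or a morpholin-4-yl group would behave on the same carbonyl carbon.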